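A few compounds are considered here, and "the series" means these few. Any claim that something is new, unique, unknown or untested is made for them only; others in the source may bear on it.

In a functional assay on PC-12 cells (Rattus norvegicus) for cytotoxicity, read by MTT assay, with stated times of 3 h and 2 h, tested at 20 uM (a lower number here means a weaker effect, a higher number a stronger effect of the compound at the concentration tested), compound 3, `O=C(CCCCC1CCSS1)NCc1cn(CCCCOc2ccc3ccc(=O)oc3c2)nn1`, gives 69.8%, the highest of the three numbers recorded. The other two sit well apart from it: compound 2, `CCOC(=O)c1cc2ccc(OCCCn3cc(CNC(=O)CCCCC4CCSS4)nn3)cc2oc1=O`, gives 42.1%, and compound 1, `CC(=O)c1cc2ccc(OCCCn3cc(CNC(=O)CCCCC4CCSS4)nn3)cc2oc1=O`, gives 39.8%. Both gaps to compound 3 lie beyond the scatter, so compound 3 counts as the strongest of the three in this assay. Among the measured compounds shown here, the only measured step, a number 2.3 percentage points higher from compound 1 to compound 2 (within the scatter), exchanged a small group on a carbonyl carbon and left the read-out essentially where it was.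

Compound 4, `O=C(CCCCC1CCSS1)NCc1cn(CCCCOc2ccc3cc(-c4ccc(Cl)c(Cl)c4)c(=O)oc3c2)nn1`, is built from compound 3 by one change: 3,4-dichlorophenyl in place of hydrogen on an aromatic carbon. For the measured compounds named here, no measured step touches this spot on the shared core, and none adds a ring of any kind, so the single measured step offers no direct guide to a substituent of this size at this place. Its only lesson, in a number 2.3 percentage points higher from compound 1 to compound 2 (within the scatter), is that one modest change elsewhere on the core moved nothing. On that slender anchor the expected step is a number 4.8 percentage points lower from compound 3 to compound 4 (within the scatter), a movement within the scatter, while the true uncertainty runs wide in both directions. The estimate for compound 4 in this assay is therefore 65%, expected to fall between 40% and 88%.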

Compound 4, a percentage reported as activity, at one concentration (the size of the read-out at that concentration, not a potency): 62.9%
Beside the measured number, compound 4's estimate is 2.1 percentage points above it; the range from low to high includes it.
By their numbers in this assay, from the lowest: compounds 1 and 2 (each within the scatter of the next); then compounds 4 and 3 (each within the scatter of the next).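

Placing 3,4-dichlorophenyl on this aromatic carbon, two atoms from the ring oxygen, gives a number 6.9 percentage points lower from compound 3 to compound 4 (within the scatter) in this assay, so a large new aromatic ring at this position leaves the two compounds indistinguishable in this read-out. Among the compounds shown here, until now, the only measured step was a small exchange on a carbonyl carbon, whereas this step shows that a substituent of far greater size can replace hydrogen here without a change beyond the scatter, at least at the single concentration tested. Nothing available bears on why the read-out held steady across this change.

The compounds shown leave open whether the two chlorine atoms matter at all, since a plain phenyl ring, a phenyl ring with a single chlorine, or one carrying an amine or a carboxylic acid would be needed to separate the ring itself from its substituents. They also leave open whether a smaller group such as methyl behaves the same way here, and whether compound 3 and compound 4 would still match at other concentrations, as one percentage at one concentration is not a measure of potency.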